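This account rests on a few compounds, and the source may have more. Where it says the series, first, only, none or still open, it means among the compounds named here.

The measured compounds in an assay for binding affinity to Alpha-1B adrenergic receptor (Homo sapiens); a lower number here means a stronger inhibitor, a higher number a weaker inhibitor:
compound 1 `CN(C)CCn1nc(Cc2ccc(Cl)cc2)c2ccccc2c1=O`, 200 nM
compound 2 `COc1cccc(Cc2nn(C[C@H]3CCCN3C)c(=O)c3ccccc23)c1`, > 1990 nM
compound 3 `O=c1c2ccccc2c(Cc2ccc(Cl)cc2)nn1C[C@H]1CCCN1CCCCCc1ccc(OCCCN2CCCCCC2)cc1`, 50.1 nM

Compound 2 stands at the edge of this assay: its entry is a limit and not a number, namely (the limit of > 1990 nM in this assay, at which 1 of the 3 values shown sits). Compound 1 gives 200 nM in this assay as a number, and compound 3 gives 50.1 nM as a number. Compound 4 `CN1CCC[C@@H]1Cn1nc(Cc2ccc(O)cc2)c2ccccc2c1=O` has not been measured. It differs from compound 2 by 4-hydroxyphenyl in place of 3-methoxyphenyl on a saturated chain carbon bound to an aromatic carbon. Among the compounds with values here, no measured pair differs in only one place, so the size of this step rests on the values shown alone. Compound 4 is estimated to give about 1500 nM in this assay, within 300 nM to 6000 nM. That estimate means an expected step of an at least 1.3-fold lower number from compound 2 to compound 4 (0.12 log units; that floor lies within the scatter) for compound 4. A limit rather than a number remains a real possibility for compound 4.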

Compound 4, inhibition constant: 398 nM
For compound 4 the middle estimate is 3.8-fold (0.58 log units) above the measured one; low and high end bracket the measured number.
By their numbers in this assay, from the lowest: compound 3; then compounds 1 and 4 (each within the scatter of the next). At a limit, above all of these: compound 2.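

In this assay, within the data shown here, 4-hydroxyphenyl in place of 3-methoxyphenyl on a saturated chain carbon bound to an aromatic carbon gives an at least 5.0-fold lower number from compound 2 to compound 4 (0.69 log units; beyond the scatter), the only readable step here, so the number does respond to a change at this place. The size of that step is only a floor, since compound 2 holds a limit and not a number: the limit of > 1990 nM in this assay, at which 1 of the 4 values shown sits. The change adds a hydrogen-bond donor and alters the substituent and its ring position together, and this single step cannot tell these apart. Still open, from the compounds shown here alone, is how 3-hydroxyphenyl or 4-methoxyphenyl would read at this place, and whether a 4-aminophenyl group would match 4-hydroxyphenyl.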